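Pyridin-4-yl in place of cyclopentyl on compound 2

The compounds below may be only part of what the source reports. "The series", "measured", "known", "first", "only" and "open" are said of these compounds alone.

Among the compounds with values here, in a physicochemical assay for lipophilicity, read by HPLC, using the shake flask method, measured as octanol-water partition (a lower number here means a more polar compound, a higher number a more lipophilic compound), compound 2 (`O=C(C1CC12CCN(C1CCOCC1)CC2)N1CCN(C2CCCC2)CC1`) gives no single number: its entry reads "not determined" (no result reported) and offers no anchor for a step. Compound 1 (`O=C(C1CC12CCN(C1CCOCC1)CC2)N1CCN(C2CC2)CC1`) is in the same position, with the entry "not determined" (no result reported) in place of a value. Within the data shown here, the only number in the set belongs to compound 3 (`O=C(C1CC12CCN(C1CCOCC1)CC2)N1CCCN(C2CCC2)CC1`), which stands at 0.18 on the shared core but differs from compound 2 in more than one place.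

Compound 4 (`O=C(C1CC12CCN(C1CCOCC1)CC2)N1CCN(c2ccncc2)CC1`) carries pyridin-4-yl in place of cyclopentyl on an amine nitrogen in a ring. Among the measured compounds shown here, a moderate step towards lower numbers in this assay is expected from compound 2 to compound 4, though no measured step in the set can size it. The expectation therefore leans on compound 3 at 0.18 as the sole reference, and a wide range is warranted. For compound 4 the estimated value is 0.3, with an expected range from -0.4 to 1 for the measurement.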

Compound 4, distribution coefficient: -1.09
Estimate against measurement, compound 4: 1.39 log units above, and the stated range ends above it.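

In this assay compound 4 gives -1.09, but compound 2 has no single number, so no step can be read between them. The compounds shown leave open how large a change pyridin-4-yl in place of cyclopentyl brings on the shared core. No evidence on hand bears on this result.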